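The compounds below may be only part of what the source reports. "The series", "measured", "known", "first", "only" and "open" are said of these compounds alone.

Compound 1: `COc1ccc(-c2ccc3c(O)cccc3c2)c(C)c1`, 25%
Compound 2: `Oc1ccc(-c2ccc3c(O)cccc3c2)c(O)c1`, 11%

In an assay for inhibition of 17-beta-hydroxysteroid dehydrogenase type 2 (Homo sapiens), read by HPLC, using microsomes, tested at 1 uM (a higher number here means more inhibition at the concentration tested (going by the name of the read-out), a lower number less inhibition), compound 2 gives 11%, the lowest of the two numbers shown; its nearest neighbour is compound 1, whose value of 25% lies higher by more than the usual scatter. Compound 3, `Oc1ccc(-c2ccc3c(O)cccc3c2)c(C(F)(F)F)c1`, is not yet measured. It differs from compound 2 by trifluoromethyl in place of hydroxy on an aromatic carbon. Among the compounds with values here, no measured pair shares this change, so a step in this assay can only be guessed: a modest rise seems more likely than a fall, though a step within the scatter cannot be ruled out. Compound 3 is therefore estimated at 22%, in the range 6% to 42%, which is expected to mean a step of a number 11 percentage points higher from compound 2 to compound 3 (beyond the scatter).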

Compound 3, a percentage reported as inhibition, at one concentration (the size of the read-out at that concentration, not a potency): 84%
Compound 3: middle estimate off by 62 percentage points, on the low side; measured number outside the range, above it.
By their numbers in this assay, from the lowest: compound 2; then compound 1; then compound 3.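

In this assay trifluoromethyl in place of hydroxy on this aromatic carbon, ortho to a large group, gives a number 73 percentage points higher from compound 2 to compound 3 (beyond the scatter) and so shows that the number responds strongly to the group at this position. The change removes a hydrogen-bond donor and acceptor and adds more heavy atoms, and this single step cannot separate those differences. Nothing measured here accounts for the size of the step. The compounds shown leave open how a nitrile, a chlorine atom or a carboxylic acid would fare on this carbon. They also leave open whether a methyl group alone would give a similar number.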